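The source may hold more compounds than are shown below. What is called first, only, known or untested is meant among the compounds shown, and "the series" means these compounds.

In an ADME assay on Vero cells (Chlorocebus sabaeus) for cytotoxicity, read by MTT assay, with a stated time of 72 h (on this read-out higher numbers stand for an effect only at larger amounts of compound and lower numbers for an effect already at smaller amounts), the measured compounds are:
Compound 1 `Cc1ccccc1C(=O)Nc1nc(-c2ccccn2)cs1` gives 6300 nM
Compound 2 `O=C(Nc1nc(-c2ccccn2)cs1)c1ccc(OCc2ccccc2)cc1` gives 2300 nM
Compound 3 `CC(=O)c1ccccc1C(=O)Nc1nc(-c2ccccn2)cs1` gives 86700 nM

Compound 3, at 86700 nM on this read-out, holds the highest number of the three, so it affects the cells only at the largest amount. Its distance to each of the other two lies beyond the scatter.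

The next compound, compound 4 `O=C(Nc1nc(-c2ccccn2)cs1)c1ccccc1Cl`, has not been measured. The change is chloro in place of acetyl on an aromatic carbon in which chloro replaces acetyl on an aromatic carbon, ortho to a large group. Among the compounds with values here, the one measured step that bears on this is a 14-fold higher number from compound 1 to compound 3 (1.14 log units; beyond the scatter) when acetyl took the place of methyl, and it was large and beyond the scatter. Within the data shown here, compound 4 loses that acetyl again, but no measured compound carries chloro, so treating chloro like the methyl of compound 1 is an assumption. A large drop in this assay is therefore expected, to a number near that of compound 1. The expected change is an 11-fold lower number from compound 3 to compound 4 (1.03 log units; beyond the scatter) in this estimate. For compound 4 the estimated value is 8000 nM within an expected range of 3000 nM to 22000 nM on this read-out.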

Compound 4, half-maximal effective concentration: 2000 nM
Estimate against measurement, compound 4: 4.0-fold (0.60 log units) above; the measured number lies below the stated range.
By their numbers in this assay, from the lowest: compounds 4 and 2 (each within the scatter of the next); then compound 1; then compound 3.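

Replacing acetyl with chloro on this aromatic carbon, ortho to a large group, gives a 43-fold lower number from compound 3 to compound 4 (1.64 log units; beyond the scatter) in this assay and shows that the high number of compound 3 does not survive with chloro in its place. Chloro and methyl, which might have been expected to read alike, can also be told apart here: the change from methyl to chloro gives a 3.2-fold lower number from compound 1 to compound 4 (0.50 log units; beyond the scatter) and is modest yet beyond the scatter, so acetyl, methyl and chloro at this one position give three distinct levels, with chloro lowest and acetyl highest. No measurement at hand explains this order, so the numbers describe it without accounting for it.

The compounds shown leave open how other groups would read at this position, for example fluoro, methoxy, an amine or a carboxylic acid, and whether any of them would reach a number as high as the one seen with acetyl. Also open, going by these compounds, is whether acetyl, methyl and chloro would keep the same order on another carbon of this ring, as all three sit at the same place in the compounds compared here.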